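The compounds below may be only part of what the source reports. "The series", "measured", "known", "first", "only" and "open" are said of these compounds alone.

In an ADME assay on L02 cells (Homo sapiens) for inhibition, read by CCK-8 assay, with a stated time of 48 h (a higher number here means a weaker inhibitor of growth, a lower number a stronger inhibitor of growth), compound 1 `CN1CCN(c2ccc(Nc3ncc(Cl)c(NCc4ccc(C(F)(F)F)cc4)n3)nc2)CC1` gives 26200 nM and compound 2 `COc1ccc(CNc2nc(Nc3ccc(N4CCN(C)CC4)cn3)ncc2Cl)cc1` gives 12900 nM. Among the measured compounds shown here, compound 2 thus holds the lower of the two numbers measured so far. The two compounds differ by methoxy in place of trifluoromethyl on an aromatic carbon, and this change gives a 2.0-fold lower number from compound 1 to compound 2 (0.31 log units; beyond the scatter), a modest step beyond the scatter. Compound 3 `CN1CCN(c2ccc(Nc3ncc(Cl)c(NCc4ccco4)n3)nc2)CC1` has not yet been measured. It carries furan-2-yl in place of 4-methoxyphenyl on a saturated chain carbon bound to a nitrogen on an aromatic ring. For the measured compounds named here, no measured compound carries furan-2-yl, so the one measured step offers only a rough guide to size. With a 2.0-fold lower number from compound 1 to compound 2 (0.31 log units; beyond the scatter) as that guide, no step beyond the scatter is expected in this assay. The estimated change is a 1.4-fold higher number from compound 2 to compound 3 (0.14 log units; within the scatter). Compound 3 is expected at 18000 nM, with an estimated range from 8000 nM to 40000 nM.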

Compound 3, concentration for 50% growth inhibition: 45700 nM
Beside the measured number, compound 3's estimate is 2.5-fold (0.40 log units) below it; measured number above the stated range.
By their numbers in this assay, from the lowest: compound 2; then compounds 1 and 3 (each within the scatter of the next).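

Among the compounds shown here, compound 3 is the first to change the ring itself at this position, on a saturated chain carbon bound to a nitrogen on an aromatic ring, rather than only the group on a six-membered ring. In this assay furan-2-yl in place of 4-methoxyphenyl gives a 3.5-fold higher number from compound 2 to compound 3 (0.55 log units; beyond the scatter) and so separates the five-membered ring from the 4-methoxyphenyl group of compound 2. Furan-2-yl in place of 4-(trifluoromethyl)phenyl gives a 1.7-fold higher number from compound 1 to compound 3 (0.24 log units; within the scatter) and so leaves compound 3 and compound 1 not told apart, which makes 4-methoxyphenyl the only one of the three groups that stands apart. Nothing shown gives a reason for these steps.

The compounds shown leave open whether the step from compound 2 to compound 3 goes with the loss of the methoxy group or with the change of ring. A plain phenyl or a thiophen-2-yl group at this place would help to separate the two.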